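The source may hold more compounds than are shown below. What is called first, only, known or untested is meant among the compounds shown, and "the series" means these compounds.

In a functional assay on SW1573 cells (Homo sapiens) for antiproliferative activity, read by sulforhodamine B assay, with a stated time of 48 h (on this read-out higher numbers stand for weaker inhibition of growth and lower numbers for stronger inhibition of growth), compound 1 `COC(=O)C#CC(O/C=C/C(=O)OC)C1CCCCC1` gives 2100 nM and compound 2 `COC(=O)C#CC(O/C=C/C(=O)OC)C(C)(C)C` gives 3000 nM while compound 3 `CCC(C)C(C#CC(=O)OC)O/C=C/C(=O)OC` gives 910 nM as the lowest number of the three. Compound 4 `COC(=O)C#CC(O/C=C/C(=O)OC)C1CC1` swaps one group of compound 3 on the shared core, with cyclopropyl in place of sec-butyl on a saturated chain carbon bound to an oxygen on an unsaturated carbon and a triple-bonded carbon as the counted change, cyclopropyl in place of sec-butyl. Swaps at that same place give the nearest guide: a 2.3-fold lower number from compound 1 to compound 3 (0.36 log units; beyond the scatter) and a 3.3-fold lower number from compound 2 to compound 3 (0.52 log units; beyond the scatter) are modest, while a 1.4-fold higher number from compound 1 to compound 2 (0.15 log units; within the scatter) stays within the scatter. Going by the values given here, no measured compound carries a cyclopropyl group, and compound 3 already holds the lowest number at 910 nM so a modest step toward a higher number is expected in this assay as a 1.8-fold higher number from compound 3 to compound 4 (0.25 log units; within the scatter) by this estimate. For compound 4 the estimated value is 1600 nM within an expected range of 600 nM to 4000 nM for repeated measurements.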

Compound 4, concentration for 50% growth inhibition: 1800 nM
The estimate for compound 4 lay 1.1-fold (0.05 log units) below the measured number; low and high end bracket the measured number.
By their numbers in this assay, from the lowest: compounds 3, 4, 1 and 2 (each within the scatter of the next, the first and the last beyond it).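

In this assay, going by these compounds alone, cyclopropyl is the only group at this position whose steps to all the others stay within the scatter: a 2.0-fold higher number from compound 3 to compound 4 (0.30 log units; within the scatter), a 1.7-fold lower number from compound 2 to compound 4 (0.22 log units; within the scatter) and a 1.2-fold lower number from compound 1 to compound 4 (0.07 log units; within the scatter). The three-membered ring therefore cannot be told apart from sec-butyl, tert-butyl or cyclohexyl here, even though sec-butyl and the other two groups are separated from one another. No available evidence accounts for these steps. Still open, from the compounds shown here alone, is how an amine, a carboxylic acid or a longer straight chain would behave on this same carbon.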